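HeLa cytotoxicity notes: from compound 3 to compound 4

The compounds below may be only part of what the source reports. "The series", "measured", "known", "first", "only" and "open" are said of these compounds alone.

Measured so far:
compound 1, `N=C(CCCn1c(Cn2c(=O)n(C3CC3)c3ccncc32)cc2cc(Cl)ccc21)NO`: in an ADME assay on HeLa cells (Homo sapiens) for cytotoxicity, read by ATP content, with a stated time of 3 days (on this read-out higher numbers stand for lower toxicity in this test and lower numbers for higher toxicity in this test), compound 1 gives > 50000 nM, which is a limit of the assay and not a number.
compound 2, `COc1ccc2c(c1)cc(Cn1c(=O)n(C3CC3)c3ccncc31)n2CCCCO`: in this assay compound 2 gives > 50000 nM, again a limit.
compound 3, `N#CCCCn1c(Cn2c(=O)n(-c3ncco3)c3ccncc32)cc2cc(Cl)ccc21`: in this assay compound 3 gives > 50000 nM, a limit as well.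

Compound 3 thus has no numerical position on the numbers shown: only a limit exists for it, and the two other values shown are limits of the same kind. The whole of the evidence is the limit of > 50000 nM in this assay, at which 3 of the 3 values shown sit. Going by the values given here, no step between measured compounds that differ in one place can be drawn, and nothing in the set separates one compound from another.

Compound 4, `CS(=O)(=O)c1ccc(-n2c(=O)n(Cc3cc4cc(Cl)ccc4n3CCCC#N)c3cnccc32)cc1`, differs from compound 3 by 4-(methylsulfonyl)phenyl in place of 1,3-oxazol-2-yl on an aromatic nitrogen. With every measured compound at the limit, there is no basis for expecting a step in either direction. The expected step that the limit leaves unreadable from compound 3 to compound 4 is none beyond the scatter. Compound 4 is expected in this assay at 60000 nM, with a range from 25000 nM to 150000 nM, most likely reported again only as a limit.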

Compound 4, half-maximal cytotoxic concentration: > 50000 nM
Compound 4 gave a limit, no number (the forecaster's own chance of this, stated with the estimate: 80%); the middle value does not contradict the limit.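

No step from compound 3 to compound 4 can be read, since both values are limits and not numbers: the limit of > 50000 nM in this assay, at which 4 of the 4 values shown sit.

The compounds shown leave open whether 4-(methylsulfonyl)phenyl in place of 1,3-oxazol-2-yl on an aromatic nitrogen changes the result in this assay, and where any compound of the series would give an actual number.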